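A few compounds are considered here, and "the series" means these few. Any claim that something is new, unique, unknown or untested is made for them only; others in the source may bear on it.

Measured so far:
- compound 1, `O=S(=O)(/C=C/c1c(F)c(F)c(F)c(F)c1F)Nc1c(F)c(F)c(F)c(F)c1F`: 35000 nM
- compound 2, `COc1cc(OC)c(/C=C/S(=O)(=O)Nc2ccc(OC)c(F)c2)c(OC)c1`: 75 nM

In a functional assay on K562 cells (Homo sapiens) for cytotoxicity, read by trypan blue exclusion, with a stated time of 96 h (a lower number here means a stronger inhibitor, a higher number a weaker inhibitor), compound 2 gives 75 nM and stands lowest of the two numbers; its nearest neighbour, compound 1, gives 35000 nM, a gap well beyond the scatter. Within the data shown here, no step between measured compounds is available that isolates a single change, so the step to compound 3 rests on the structural change alone.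

Compound 3, `COc1cc(OC)c(/C=C/S(=O)(=O)Nc2ccc(OC)c(NC(C(=O)O)c3ccc(F)cc3)c2)c(OC)c1`, differs from compound 2 as follows: (carboxy(4-fluorophenyl)methyl)amino in place of fluoro on an aromatic carbon

With nothing measured on this change, the step from compound 2 to compound 3 is expected to be small, a 2.0-fold higher number from compound 2 to compound 3 (0.30 log units; within the scatter), and not clearly beyond the scatter in either direction. Compound 3 is therefore estimated at 150 nM in this assay, within a range of 30 nM to 800 nM.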

Compound 3, half-maximal inhibitory concentration: 20 nM
Compound 3: the middle estimate sits 7.5-fold (0.88 log units) above what was measured, and the stated range ends above it.
By their numbers in this assay, from the lowest: compound 3; then compound 2; then compound 1.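

In this assay the aromatic carbon ortho to a methoxy group turns out to carry far more than a fluoro without any loss. Putting (carboxy(4-fluorophenyl)methyl)amino there in place of fluoro brings a modest gain that clears the scatter (a 3.8-fold lower number from compound 2 to compound 3 (0.57 log units; beyond the scatter)), so a large group with a ring and a carboxylic acid is accepted at this position on this core. Nothing available accounts for that gain.

The compounds shown leave open which part of the new group matters: whether a plain amine on this carbon would do as well, or whether the carboxylic acid or the 4-fluorophenyl ring is needed. They also leave open whether a methyl ester in place of the acid, or a longer chain between the nitrogen and the acid, would keep the number this low.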